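Taking one fluoro group off compound 3

This account rests on a few compounds, and the source may have more. Where it says the series, first, only, none or still open, it means among the compounds named here.

Compound 1 `CC(NC(=O)c1nc(Cc2ccccc2C(F)(F)F)n(C)c(=O)c1O)c1ccccc1`: > 100000 nM
Compound 2 `COc1c(C(=O)NCc2ccccc2)nc(Cc2ccccc2C(F)(F)F)n(C)c1=O`: > 100000 nM
Compound 3 `Cn1c(Cc2ccccc2C(F)(F)F)nc(C(=O)NCc2ccc(F)cc2)c(O)c1=O`: > 100000 nM
Compound 4 `Cn1c(Cc2ccccc2C(F)(F)F)nc(C(=O)NCc2ccccc2)c(O)c1=O`: not yet measured

All three measured results in an ADME assay on HepG2 cells (Homo sapiens) for cytotoxicity, in the presence of a further agent that is not named here (a higher number here means a weaker inhibitor, a lower number a stronger inhibitor), are limits rather than numbers: the limit of > 100000 nM in this assay, at which 3 of the 3 values shown sit. Compound 3 stands at > 100000 nM, which is a limit. Compound 4 differs from it by hydrogen in place of fluoro on an aromatic carbon, with hydrogen in place of fluoro on an aromatic carbon, para to a large group. Going by the values given here, the only measured step involving the 4-fluorobenzyl group is a step that the two limits leave unreadable from compound 1 to compound 3, so it gives no size to carry over. No change beyond the scatter is therefore expected in this assay, and another limit is the likely result. The expected result is a number no higher from compound 3 to compound 4 (the limit leaves the size open). For compound 4 the estimate is 100000 nM, with an expected range of 50000 nM to 200000 nM.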

Compound 4, half-maximal inhibitory concentration: > 100000 nM
Compound 4 was reported as a limit (the forecaster's own chance of this, stated with the estimate: 90%); the middle value lies on the limit itself.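

Compounds 1, 2, 3 and 4 all sit at the same limit, so no step between them can be read in this assay: the limit of > 100000 nM in this assay, at which 4 of the 4 values shown sit.

On these data alone, how far past that limit each compound lies, and whether swapping fluoro for hydrogen changes anything, stays open.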